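A few compounds are considered here, and "the series" means these few. Any claim that something is new, unique, unknown or untested is made for them only; others in the source may bear on it.

Measured in a physicochemical assay for solubility, read by HPLC, using the shake flask method, measured as kinetic solubility, with a stated time of 20 h, at pH 6.5, tested at 200 uM; a lower number here means a less soluble compound, a higher number a more soluble compound:
- Compound 1 `C[C@@H](CO)NS(=O)(=O)c1cccc(-c2ccc3nccc(-c4ccncc4)c3n2)c1`: 50000 nM
- Compound 2 `O=S(=O)(NCC1COC1)c1cccc(-c2ccc3nccc(-c4ccncc4)c3n2)c1`: 20000 nM
- Compound 3 `O=S(=O)(CCO)c1cccc(-c2ccc3nccc(-c4ccncc4)c3n2)c1`: 55000 nM

Compound 3 stands level with compound 1 at the upper end of these three numbers, with a 1.1-fold higher number from compound 1 to compound 3 (0.04 log units; within the scatter). Compound 2 lies lower, with a 2.8-fold higher number from compound 2 to compound 3 (0.44 log units; beyond the scatter).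

The next compound is compound 4 `O=S(=O)(c1cccc(-c2ccc3nccc(-c4ccncc4)c3n2)c1)N1CCC(O)CC1`. It carries 4-hydroxypiperidin-1-yl in place of 2-hydroxyethyl on a sulfonyl sulfur. The same difference, cut one bond further out, reads (2-hydroxyethyl)sulfonyl to (4-hydroxypiperidin-1-yl)sulfonyl.

Among the measured compounds shown here, two measured steps touch this same place, and they disagree in size. For the measured compounds named here, the exchange linking compound 1 with compound 3 stays within the scatter, while the one linking compound 2 with compound 3 is modest. A third step, a 2.5-fold lower number from compound 1 to compound 2 (0.40 log units; beyond the scatter), shows that changing the group on a sulfonamide nitrogen can also move the number modestly. Going by the values given here, no measured compound carries 4-hydroxypiperidin-1-yl, so the data leave the size of this step open. A modest fall is the most likely outcome, with no change beyond the scatter still possible. The expected step is a 2.8-fold lower number from compound 3 to compound 4 (0.44 log units; beyond the scatter). The estimate for compound 4 is 20000 nM, with an expected range from 6000 nM to 55000 nM.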

Compound 4, solubility: 10000 nM
Estimate against measurement, compound 4: 2.0-fold (0.30 log units) above, and the stated range covers the measured number.
By their numbers in this assay, from the lowest: compounds 4 and 2 (each within the scatter of the next); then compounds 1 and 3 (each within the scatter of the next).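

Placing 4-hydroxypiperidin-1-yl on the sulfonyl sulfur in place of 2-hydroxyethyl gives a larger step in this assay than any among the earlier compounds (a 5.5-fold lower number from compound 3 to compound 4 (0.74 log units; beyond the scatter)), and the step from the sulfonamide with the open chain is of similar size (a 5.0-fold lower number from compound 1 to compound 4 (0.70 log units; beyond the scatter)). Set against the (oxetan-3-yl)methyl sulfonamide, the new group gives only a 2.0-fold lower number from compound 2 to compound 4 (0.30 log units; within the scatter) and cannot be told apart from it, so the two compounds with a ring in this group sit together at the low end, while the two with an open hydroxyl-bearing chain sit together at the upper end. Among the compounds shown here, compound 4 also goes against any reading of the earlier compounds in which a hydroxyl alone keeps the number high, since it carries a hydroxyl and still sits at the low end.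

The compounds shown leave open whether the fall follows the ring itself, its size or the place of the hydroxyl on it. A piperidin-1-yl without the hydroxyl, a morpholin-4-yl or a longer hydroxyalkyl chain on the sulfonyl sulfur would bear on that question. No other measurement shown here speaks to what lies behind these steps.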